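Enantiomer of the leucine-derived thiourea in the cytotoxicity series

The compounds below may be only part of what the source reports. "The series", "measured", "known", "first", "only" and "open" are said of these compounds alone.

Measured compounds:
compound 1 `CC(C)[C@H](NC(=S)Nc1cc(C(F)(F)F)cc(C(F)(F)F)c1)c1nc2ccccc2[nH]1` – 25100 nM
compound 2 `C[C@H](NC(=S)Nc1cc(C(F)(F)F)cc(C(F)(F)F)c1)c1nc2ccccc2[nH]1` – 220000 nM
compound 3 `CC(C)C[C@@H](NC(=S)Nc1cc(C(F)(F)F)cc(C(F)(F)F)c1)c1nc2ccccc2[nH]1` – 10200 nM

In a functional assay on A549 cells (Homo sapiens) for cytotoxicity, read by MTT assay (a lower number here means a stronger inhibitor, a higher number a weaker inhibitor), compound 3 gives the lowest number of the three, with compound 1 nearest and compound 2 furthest. Within the data shown here, the only measured step, an 8.8-fold higher number from compound 1 to compound 2 (0.94 log units; beyond the scatter), concerns the size of the group on the chain carbon, not its configuration. Compound 4 `CC(C)C[C@H](NC(=S)Nc1cc(C(F)(F)F)cc(C(F)(F)F)c1)c1nc2ccccc2[nH]1` differs from compound 3 as follows: the two compounds have the same atoms and bonds and differ only in configuration as drawn: 1 of 1 stereo elements differ; a stereocentre at a saturated chain carbon is drawn R in compound 3 and S in compound 4. Among the measured compounds shown here, no step between two compounds of opposite configuration has been measured, so nothing bears directly on this change; an inversion may leave the number close to that of compound 3 or move it in either direction. Compound 4 is therefore estimated at 20000 nM, range 6000 nM to 80000 nM, which is expected to mean a 2.0-fold higher number from compound 3 to compound 4 (0.29 log units; within the scatter).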

Compound 4, half-maximal inhibitory concentration: 17400 nM
Estimate against measurement, compound 4: 1.1-fold (0.06 log units) above, and the stated range covers the measured number.
By their numbers in this assay, from the lowest: compounds 3, 4 and 1 (each within the scatter of the next, the first and the last beyond it); then compound 2.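

The chain carbon now has its first reading on configuration: in this assay inversion gives a 1.7-fold higher number from compound 3 to compound 4 (0.23 log units; within the scatter) and so does not separate the pair, a clean comparison at this position: the fact that compounds 3 and 4 differ only in the configuration as drawn. The size of the group still matters at this carbon, with a 13-fold lower number from compound 2 to compound 4 (1.10 log units; beyond the scatter) against a 1.4-fold lower number from compound 1 to compound 4 (0.16 log units; within the scatter) within the scatter, so isobutyl and isopropyl are not separated while methyl stands apart.

Open, as far as these compounds go, is whether inversion reads the same with the isopropyl or methyl groups. Also open, from the compounds shown here alone, is how a longer chain or a carboxylic acid at this carbon would read.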